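Removing the fluorobenzyl group from a weakly cytotoxic amide

The source may hold more compounds than are shown below. What is called first, only, known or untested is meant among the compounds shown, and "the series" means these compounds.

Compound 1 `Cc1ccc2c(NCc3ccc(NC(=O)C4CCN(Cc5ccc(F)cc5)CC4)cc3)nc(N(C)C)nc2c1` carries a 4-fluorobenzyl group on the ring amine nitrogen and a dimethylamino group on the shared core. In a functional assay on SV5A8 cells (Homo sapiens) for cytotoxicity (a lower number here means a stronger inhibitor, a higher number a weaker inhibitor), compound 1 gives only a limit, > 4820 nM, and no number. Compound 2 `Cc1ccc2c(NCc3ccc(NC(=O)C4CCN(Cc5ccccc5)CC4)cc3)nc(N3CCNC(CCO)C3)nc2c1` likewise gives only a limit in this assay, > 8420 nM. Compound 3 `Cc1ccc2c(NCc3ccc(NC(=O)C4CCN(Cc5ccccc5)CC4)cc3)nc(N(C)CCCN(C)C)nc2c1` also gives only a limit in this assay, > 8620 nM. Among the compounds with values here, the one comparison between measured compounds, a step that the two limits leave unreadable from compound 2 to compound 3, concerns the core and cannot be read. As the limit of > 4820 nM in this assay, at which 1 of the 3 values shown sits, the limit of > 8420 nM in this assay, at which 1 of the 3 values shown sits, and the limit of > 8620 nM in this assay, at which 1 of the 3 values shown sits, show, every value in the set is a limit, so no potency ranking exists.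

Compound 4 `Cc1ccc2c(NCc3ccc(NC(=O)C4CCN(C)CC4)cc3)nc(N(C)C)nc2c1` differs from compound 1 by hydrogen in place of 4-fluorophenyl on a saturated chain carbon bound to an amine nitrogen in a ring. Within the data shown here, no measured step touches the ring amine nitrogen, and the single recorded step is unreadable, so the data give no direction and no size for this change. The expectation rests only on the fact that compound 1 sits at a limit. Compound 4 is therefore expected to give about 10000 nM, with a range from 3000 nM to 40000 nM, most likely again as a limit. This estimate means a step that the limit leaves unreadable from compound 1 to compound 4, which is expected to be no step beyond the scatter.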

Compound 4, half-maximal inhibitory concentration: > 17300 nM
Compound 4: only a limit was reported (the forecaster's own chance of this, stated with the estimate: 80%); middle value at least 1.7-fold (0.23 log units) from the limit.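

In this assay compound 4 gives only a limit, > 17300 nM. Compound 1 also gives only a limit, and the step between compound 1 and compound 4 cannot be read. The compounds shown leave open whether 4-fluorobenzyl to methyl changes the value at all, and how any of the compounds rank against each other.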